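Swapping the aryl group on the triazole of a hydroxamic acid

This account rests on a few compounds, and the source may have more. Where it says the series, first, only, none or still open, it means among the compounds named here.

Of the compounds shown here, two have been tested in an assay on Sf9 cells for inhibition of protein deacetylase HDAC6 (Homo sapiens), read by fluorescence, with a stated time of 40 min, tested at 100 nM; a higher number here means more inhibition at the concentration tested (going by the name of the read-out), a lower number less inhibition. Compound 1 `O=C(NO)c1ccc(NCc2nc(-c3ccc(Br)cc3)nn2-c2ccccc2)cc1` gives 54.7%, and compound 2 `Cc1cccc(-c2nc(CNc3ccc(C(=O)NO)cc3)n(-c3ccccc3)n2)c1` gives 64.1%. Within the data shown here, compound 2 stands at the top of these two numbers, but its gap to compound 1 is small: the single step of a number 9.4 percentage points higher from compound 1 to compound 2 (within the scatter), so the two cannot be told apart on this evidence.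

Compound 3 `O=C(NO)c1ccc(NCc2nc(-c3ccccc3Cl)nn2-c2ccccc2)cc1` has not yet been measured. It differs from compound 2 in one place: 2-chlorophenyl in place of 3-methylphenyl on an aromatic carbon. Among the measured compounds shown here, the only measured step bearing on this position is the one from compound 1 to compound 2, where a change of the same aryl group moved the number by a number 9.4 percentage points higher from compound 1 to compound 2 (within the scatter), which is within the scatter. On that basis, a second swap of the aryl group is expected to leave the result in this assay roughly where compound 2 lies, with no clear shift in either direction beyond the scatter; the expected step is a number 6.1 percentage points lower from compound 2 to compound 3 (within the scatter). For compound 3 the estimated result in this assay is 58%, likely between 38% and 76%.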

Compound 3, a percentage reported as inhibition, at one concentration (the size of the read-out at that concentration, not a potency): 75%
Beside the measured number, compound 3's estimate is 17 percentage points below it, within the range that was stated.
By their numbers in this assay, from the lowest: compounds 1 and 2 (each within the scatter of the next); then compound 3.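

At this position on the five-membered aromatic ring, the earlier pair left open whether the aryl group matters at all, but in this assay the move to 2-chlorophenyl gives a number 10.9 percentage points higher from compound 2 to compound 3 (beyond the scatter), and the swap from 4-bromophenyl gives a number 20.3 percentage points higher from compound 1 to compound 3 (beyond the scatter), so both steps clear the usual scatter, if only modestly. The step from 3-methylphenyl to 2-chlorophenyl keeps the count of heavy atoms, adds no hydrogen-bond donors or acceptors and leaves the charge unchanged, so the number can move at this position even when those counts stay the same. Nothing at hand explains the rise.

The compounds shown change the substituent and its place on the phenyl ring together, so they cannot separate the effect of the chlorine from the effect of where it sits, and a methoxy group or an amine on that ring remains untested in this set. These are also readings at a single concentration, so they leave open how far the rise would carry over to a true measure of potency.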